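Swapping phenyl for thiophen-2-yl on a hydrazone core

A few compounds are considered here, and "the series" means these few. Any claim that something is new, unique, unknown or untested is made for them only; others in the source may bear on it.

Of the compounds shown here, three sharing one core have been measured in an assay on isolated protein for inhibition of Amine oxidase [flavin-containing] A (Homo sapiens), read by spectrophotometry; on this read-out higher numbers stand for weaker inhibition and lower numbers for stronger inhibition. Compound 1 `COc1ccccc1/C=N/Nc1nc2ccccc2nc1Cc1ccccc1` gives 83 nM in this assay. Compound 2 `C/C(=N\Nc1nc2ccccc2nc1Cc1ccccc1)c1ccccc1` gives 79 nM. Compound 3 `CN(C)c1ccc(/C=N/Nc2nc3ccccc3nc2Cc2ccccc2)cc1` gives 83 nM. On the numbers shown, compound 2 stands alongside compound 1 and compound 3, all three falling within the usual scatter of one another. Among the measured compounds shown here, the one measured step, no change at the digits printed from compound 1 to compound 3 (within the scatter), shows that exchanging one aromatic group for another on the carbon that is double-bonded to nitrogen left this assay unmoved.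

Compound 4 `C/C(=N\Nc1nc2ccccc2nc1Cc1ccccc1)c1cccs1` differs from compound 2 by thiophen-2-yl in place of phenyl on a carbon with a double bond to nitrogen. This change touches the same carbon as the step from compound 1 to compound 3, which carried no change beyond the scatter, so no step beyond the scatter is expected here either, in either direction. Compound 4 is therefore estimated at 80 nM in this assay, between 40 nM and 160 nM, an expected step of a 1.0-fold higher number from compound 2 to compound 4 (0.01 log units; within the scatter).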

Compound 4, half-maximal inhibitory concentration: 64 nM
For compound 4 the middle estimate is 1.3-fold (0.10 log units) above the measured one; measured number inside the range.
By their numbers in this assay, from the lowest: compounds 4, 2, 1 and 3 (each within the scatter of the next).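

In this assay, the step from compound 1 to compound 3 exchanged only one substituted phenyl for another, whereas this change alters the ring itself on the carbon with a double bond to nitrogen. Replacing the six-membered all-carbon phenyl with thiophen-2-yl, a five-membered aromatic ring containing sulfur, gives a 1.2-fold lower number from compound 2 to compound 4 (0.09 log units; within the scatter), so a different ring type also leaves this assay within the scatter. Nothing measured here explains this result.

On these data alone, it remains open whether this position would stay as unresponsive with something other than an aromatic ring, such as an amine, a carboxylic acid or a longer chain. All four compounds also share the same core, so how changes to that core would read in this assay is open too.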